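Amino in place of chloro on the shared core

The source may report more compounds than this note shows. Statements on the series, on what has been measured and on what is new or still open speak of the compounds shown alone.

Compound 1 `Nc1nn(C(=O)Nc2ccc(Cc3ccccc3)cc2)c2ccccc12` gives 2940 nM in a functional assay on KM12 cells (Homo sapiens) for antiproliferative activity, read by sulforhodamine B assay, with a stated time of 48 h; a lower number here means a stronger inhibitor of growth, a higher number a weaker inhibitor of growth.
Compound 2 `Nc1nn(C(=O)Nc2ccc(Cc3ccccc3)cc2)c2ccc(Cl)cc12` gives 72.6 nM in this assay.

Of these two numbers, compound 2 stands at the lowest, and compound 1 is its nearest neighbour. Among the compounds with values here, the one measured step, a 40-fold lower number from compound 1 to compound 2 (1.61 log units; beyond the scatter), shows that the carbon on which the chloro sits is a position where a single change moves the number a long way.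

Compound 3 `Nc1ccc2c(c1)c(N)nn2C(=O)Nc1ccc(Cc2ccccc2)cc1` differs from compound 2 at exactly that position: amino in place of chloro on an aromatic carbon. Within the data shown here, no measured step covers an amino there, so only the size of the chloro step offers guidance. Amino is not hydrogen, yet it is a different group from chloro, bringing a hydrogen-bond donor and acceptor where chloro had none, so some of the large gain seen with chloro may be lost. Compound 3 is therefore expected to give about 1000 nM, within 200 nM to 5000 nM. That estimate means a step of a 14-fold higher number from compound 2 to compound 3 (1.14 log units; beyond the scatter).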

Compound 3, concentration for 50% growth inhibition: 3340 nM
The estimate for compound 3 lay 3.3-fold (0.52 log units) below the measured number, and the stated range covers the measured number.
By their numbers in this assay, from the lowest: compound 2; then compounds 1 and 3 (each within the scatter of the next).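

Placing amino where chloro stood gives a 46-fold higher number from compound 2 to compound 3 (1.66 log units; beyond the scatter), so the large gain seen with chloro does not extend to every group on this aromatic carbon. Amino in place of hydrogen gives a 1.1-fold higher number from compound 1 to compound 3 (0.06 log units; within the scatter), so amino and hydrogen cannot be told apart here in this assay, and of the three groups seen at this position, only chloro stands out. Nothing available explains why chloro and amino differ so much at this carbon.

Going by these compounds, it remains open whether other halogens, such as fluoro or bromo, would behave like chloro at this carbon. Also open, on these data alone, is where a methyl, a methoxy or a hydroxyl group would fall, and whether any of them would match chloro or stay with hydrogen and amino.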